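Bromo in place of hydrogen: expectation for compound 4

A few compounds are considered here, and "the series" means these few. Any claim that something is new, unique, unknown or untested is made for them only; others in the source may bear on it.

Compound 1 `O=C(/C=C/c1ccccc1)c1ccc[nH]1` is the unsubstituted parent of the series. In a functional assay on HeLa cells (Homo sapiens) for inhibition, read by MTT assay, with a stated time of 48 h (on this read-out lower numbers stand for stronger inhibition and higher numbers for weaker inhibition), compound 1 reaches only the assay limit of > 100000 nM, a limit and not a number. In this assay compound 2 `O=C(/C=C/c1ccc([N+](=O)[O-])cc1)c1ccc[nH]1` gives 26000 nM. In this assay compound 3 `O=C(/C=C/c1cccc([N+](=O)[O-])c1)c1ccc[nH]1` gives 32000 nM. The two substitution steps measured so far are an at least 3.8-fold lower number from compound 1 to compound 2 (0.58 log units; beyond the scatter) and an at least 3.1-fold lower number from compound 1 to compound 3 (0.49 log units; beyond the scatter); both are capped in size by the limit of > 100000 nM in this assay, at which 1 of the 3 values shown sits. Compound 4 `O=C(/C=C/c1ccccc1Br)c1ccc[nH]1` differs from compound 1 by bromo in place of hydrogen on an aromatic carbon. Only the nitro steps bear on this change, and they carry a different group; a smaller step is expected, an at least 1.6-fold lower number from compound 1 to compound 4 (0.22 log units; that floor lies within the scatter). The estimate for compound 4 in this assay is 60000 nM, with a range from 20000 nM to 200000 nM.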

Compound 4, half-maximal inhibitory concentration: 44000 nM
Compound 4: the middle estimate sits 1.4-fold (0.13 log units) above what was measured; the measured number falls inside the stated range.
By their numbers in this assay, from the lowest: compounds 2, 3 and 4 (each within the scatter of the next). At a limit, above all of these: compound 1.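

Bromo on an aromatic carbon ortho to a group of 9 heavy atoms gives an at least 2.2-fold lower number from compound 1 to compound 4 (0.35 log units; beyond the scatter) in this assay and shows that, among the compounds shown, a step beyond the scatter is not confined to nitro. The step also shows that this position tolerates substitution without loss of the lower number. Its size remains a floor: the limit of > 100000 nM in this assay, at which 1 of the 4 values shown sits.

Open, as far as these compounds go, are the effect of bromo on the other carbons of this ring and the effect of an amine or a carboxylic acid on this same carbon. How far the true step exceeds its floor also stays unsettled.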